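Swapping methylsulfanyl for trifluoromethoxy in a urea series

The source may report more compounds than this note shows. Statements on the series, on what has been measured and on what is new or still open speak of the compounds shown alone.

Measured compounds:
compound 1 `CSc1ccc(NC(=O)Nc2cc(C)nc3ccccc23)cc1` — 16000 nM
compound 2 `Cc1cc(NC(=O)Nc2cnc3ccccc3c2)c2ccccc2n1` — > 25000 nM

Two ureas on a shared core were tested in an ADME assay on HepG2 cells (Homo sapiens) for cytotoxicity, with a stated time of 72 h; a lower number here means that less compound is needed, a higher number that more compound is needed for the effect. Among the compounds with values here, compound 1 `CSc1ccc(NC(=O)Nc2cc(C)nc3ccccc23)cc1` gives 16000 nM in this assay, the only number the set holds. Compound 2 `Cc1cc(NC(=O)Nc2cnc3ccccc3c2)c2ccccc2n1` reaches only the limit of this assay, > 25000 nM, so no number is known for it; this is the limit of > 25000 nM in this assay, at which 1 of the 2 values shown sits. Within the data shown here, with one number and one limit, no step between measured compounds can be drawn.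

Compound 3 `Cc1cc(NC(=O)Nc2ccc(OC(F)(F)F)cc2)c2ccccc2n1` differs from compound 1 in a single place: trifluoromethoxy in place of methylsulfanyl on an aromatic carbon. Among the measured compounds shown here, no measured pair shows what this exchange does in this assay, so no step beyond the usual scatter is expected in either direction. On that basis compound 3 is estimated at 18000 nM in this assay, within a range of 8000 nM to 40000 nM, which would mean an expected step of a 1.1-fold higher number from compound 1 to compound 3 (0.05 log units; within the scatter).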

Compound 3, half-maximal effective concentration: 15000 nM
For compound 3 the middle estimate is 1.2-fold (0.08 log units) above the measured one; the measured number falls inside the stated range.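

In this assay, within the data shown here, trifluoromethoxy in place of methylsulfanyl on an aromatic carbon, para to a large group, gives a 1.1-fold lower number from compound 1 to compound 3 (0.03 log units; within the scatter), the first measured reading of this exchange. In this one pair, then, the position takes a group of 5 heavy atoms in place of one of 2 heavy atoms with no step beyond the usual scatter. Nothing at hand gives a cause for this outcome.

On these data alone, whether the same holds for other groups at this place, such as an amine or a carboxylic acid, stays open. A single pair on a single core also cannot show whether this exchange would read the same on another core.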